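Chloro step from compound 3 to compound 4

A few compounds are considered here, and "the series" means these few. Any claim that something is new, unique, unknown or untested is made for them only; others in the source may bear on it.

Measured in a functional assay on NALM-6 cells (Homo sapiens) for cytotoxicity, with a stated time of 72 h; a lower number here means that less compound is needed, a higher number that more compound is needed for the effect:
- compound 1 `C=C[C@@](C)(/C=C/c1ccc(Nc2ccc(Cl)cc2)cc1)CCC=C(C)C`: > 43400 nM (a limit)
- compound 2 `C=C[C@@](C)(/C=C/c1ccc(Nc2ccc(Cl)c(Cl)c2)cc1)CCC=C(C)C`: > 43400 nM (a limit)
- compound 3 `C=C[C@@](C)(/C=C/c1ccc(-c2ccccc2)cc1)CCC=C(C)C`: > 43400 nM (a limit)

Compound 3 gives > 43400 nM in this assay, and this is a limit and not a number. The same holds for the whole set: the limit of > 43400 nM in this assay, at which 3 of the 3 values shown sit. For the measured compounds named here, no compound measured so far has a numerical value.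

Compound 4 `C=C[C@@](C)(/C=C/c1ccc(-c2ccc(Cl)cc2)cc1)CCC=C(C)C` differs from compound 3 in one place: chloro in place of hydrogen on an aromatic carbon. The change is phenyl to 4-chlorophenyl.

Going by the values given here, the closest precedent is the same kind of change, chloro in place of hydrogen on an aromatic carbon, seen in a step that the two limits leave unreadable from compound 1 to compound 2. Two further steps bear on the phenyl group itself: a step that the two limits leave unreadable from compound 1 to compound 3 and a step that the two limits leave unreadable from compound 2 to compound 3. None of the three has a readable size, so none supports a direction. The expectation in this assay is therefore no step beyond the scatter, and the most likely result is another limit.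

The expected size is a step that the limit leaves unreadable from compound 3 to compound 4.

For compound 4 the estimated value is 45000 nM, with an expected range of 15000 nM to 100000 nM.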

Compound 4, half-maximal effective concentration: > 43400 nM
Compound 4 was reported as a limit; the forecaster's own chance of this, stated with the estimate: 75%; the middle value lies beyond the limit too.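

In this assay compound 4 gives > 43400 nM, which is a limit and not a number. The steps linking compound 4 to compound 1, compound 2 and compound 3 cannot be read, and the whole set stays at one limit: the limit of > 43400 nM in this assay, at which 4 of the 4 values shown sit.

The compounds shown leave open what numerical value any of the four has in this assay, and so whether chloro in place of hydrogen shifts that value at all.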